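The source may report more compounds than this note shows. Statements on the series, on what has been measured and on what is new or still open speak of the compounds shown alone.

The compounds measured so far:

Compound 1, `CS(=O)(=O)c1ccc(C(=O)NCCC(=O)N2CCCc3ccccc32)cc1[N+](=O)[O-]`, gives in an assay on isolated protein for inhibition of thyroid hormone receptor beta (Homo sapiens), read by fluorescence polarization; a lower number here means a stronger inhibitor, a higher number a weaker inhibitor > 60000 nM, which is a limit of the assay rather than a number.
Compound 2, `CS(=O)(=O)c1ccc(C(=O)NCCC(=O)N2CCc3ccccc32)cc1[N+](=O)[O-]`, gives in this assay > 60000 nM, again only a limit.
Compound 3, `CC1CCN(C(=O)CCNC(=O)c2ccc(S(C)(=O)=O)c([N+](=O)[O-])c2)CC1`, gives in this assay > 60000 nM, also a limit.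

Compound 3 therefore stands where every measured compound stands: at the limit of > 60000 nM in this assay, at which 3 of the 3 values shown sit. Because all three values are limits, the three exchanges of the ring on the carbonyl carbon cannot be sized: a step that the two limits leave unreadable from compound 1 to compound 2, a step that the two limits leave unreadable from compound 1 to compound 3 and a step that the two limits leave unreadable from compound 2 to compound 3 are all unreadable. Compound 4, `CS(=O)(=O)c1ccc(C(=O)NCCC(=O)N2CCc3ccccc3C2)cc1[N+](=O)[O-]`, is not yet measured; it differs from compound 3 in one place, (1,2,3,4-tetrahydroisoquinolin-2-yl in place of 4-methylpiperidin-1-yl on a carbonyl carbon). Each measured step bears on this change only in that a ring of this kind was swapped in every measured pair without any compound leaving the limit, so no step beyond the scatter can be predicted in either direction. Compound 4 is expected to give 100000 nM, with a range from 30000 nM to 300000 nM, most likely again only as a limit. The expected step is a step that the limit leaves unreadable from compound 3 to compound 4.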

Compound 4, half-maximal inhibitory concentration: > 60000 nM
Compound 4 gave a limit, no number; the forecaster's own chance of this, stated with the estimate: 90%; the middle value lies beyond the limit too.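

Compound 4 also gives only a limit, so the steps to it from compound 1, compound 2 and compound 3 cannot be read: the limit of > 60000 nM in this assay, at which 4 of the 4 values shown sit. The compounds shown leave open whether any ring on this carbonyl carbon can give a readable number in this assay at all.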